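The source may report more compounds than this note shows. Statements on the series, on what has been measured and on what is new or still open speak of the compounds shown alone.

Two compounds measured in a functional assay on KB 3-1 cells (Homo sapiens) for cytotoxicity, read by MTT assay, with a stated time of 68 h (on this read-out lower numbers stand for stronger inhibition and higher numbers for weaker inhibition), give the starting point. Compound 1 `O=C(Nc1cccc(-c2ccc(F)cc2)c1)C(Cl)Cl` gives 26200 nM in this assay. Compound 2 `Nc1cccc(-c2cccc(NC(=O)C(Cl)Cl)c2)c1` gives 26100 nM in this assay. These two numbers sit within the scatter of each other, so neither compound can be called weaker or stronger than the other; both show only modest cytotoxicity at these concentrations.

Compound 3 `O=C(Nc1cccc(-c2ccc(-c3ccccc3)cc2)c1)C(Cl)Cl` has not yet been measured in this assay. Compared with compound 1, the change is phenyl in place of fluoro on an aromatic carbon. Among the compounds with values here, no pair of measured compounds differs in exactly this way, so the two measured values say nothing direct about what a phenyl does at that site.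

Within the data shown here, with only one number for compound 1 and no comparable step to lean on, the expectation for compound 3 is an estimated step from a 1.3-fold lower number from compound 1 to compound 3 (0.12 log units; within the scatter) that stays close to what the scatter allows, with no clear direction. Compound 3 is therefore expected to give about 20000 nM in this assay, within a range of 6000 nM to 70000 nM.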

Compound 3, half-maximal inhibitory concentration: > 50000 nM
Compound 3: a limit, no number; the forecaster's own chance of this, stated with the estimate: 15%; middle value at least 2.5-fold (0.39 log units) away from the limit.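

In this assay compound 3 gives > 50000 nM, which is a limit of the assay and not a number. Phenyl in place of fluoro, on an aromatic carbon para to a large group, comes with an at least 1.9-fold higher number from compound 1 to compound 3 (0.28 log units; that floor lies within the scatter), so the true step may be larger, although this floor alone does not separate the two compounds. Within the data shown here, this is the first reading of any change at this position, and it shows that the phenyl group brings no lower number in this assay, something the earlier compounds could not show.

As far as these compounds go, how far the value of compound 3 lies past the limit remains unknown, so the real size of the step from fluoro to phenyl stays open. A single change at this carbon also cannot show how other groups there would behave, such as a methoxy group or a carboxylic acid, or whether only a group as large as phenyl moves the number away from that of compound 1.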